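A few compounds are considered here, and "the series" means these few. Any claim that something is new, unique, unknown or untested is made for them only; others in the source may bear on it.

Measured compounds:
compound 1 `CC(C)c1onc(-c2c(Cl)cccc2Cl)c1COc1ccc(-c2nc3ccc(C(=O)O)cc3n2C2CCCCCC2)cc1` with 14.8 nM
compound 2 `CC(C)c1onc(-c2c(Cl)cccc2Cl)c1COc1ccc(-c2nc3ccc(C(=O)O)cc3n2CC2CCCCC2)cc1` with 0.52 nM

Both were tested in an assay on Huh-7 cells for agonist activity at Bile acid receptor (Homo sapiens), read by a luciferase reporter; on this read-out lower numbers stand for an effect already at smaller amounts and higher numbers for an effect only at larger amounts of compound. Compound 2 holds the lowest of the two numbers; the nearest is compound 1 at a value higher by the step of a 28-fold lower number from compound 1 to compound 2 (1.45 log units; beyond the scatter). For the measured compounds named here, that step is the only one so far, and it records what happens on the aromatic nitrogen of the shared core when cycloheptyl gives way to cyclohexylmethyl.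

Compound 3 `CC(=O)N1CCC(n2c(-c3ccc(OCc4c(-c5c(Cl)cccc5Cl)noc4C(C)C)cc3)nc3ccc(C(=O)O)cc32)CC1` is not yet measured in this assay. It differs from compound 2 in one place: 1-acetylpiperidin-4-yl in place of cyclohexylmethyl on an aromatic nitrogen. The group that enters is again a six-membered ring joined directly to the aromatic nitrogen, as in compound 1, while the methylene link of compound 2 is gone; in addition the ring now carries a heteroatom and an acetyl group. Going by the values given here, the one measured step, a 28-fold lower number from compound 1 to compound 2 (1.45 log units; beyond the scatter), shows that moving from a directly attached ring to the methylene-linked ring lowered the number strongly. Among the compounds with values here, no step covers the added heteroatom or the acetyl. Reversing the attachment pattern is therefore expected to raise the number in this assay again, by roughly a 19-fold higher number from compound 2 to compound 3 (1.28 log units; beyond the scatter), though the size is uncertain. For compound 3 the estimate in this assay is 10 nM, with a range from 2 nM to 60 nM.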

Compound 3, half-maximal effective concentration: 1430 nM
Estimate against measurement, compound 3: 140-fold (2.16 log units) below; measured number above the stated range.
By their numbers in this assay, from the lowest: compound 2; then compound 1; then compound 3.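

In this assay, this position on the aromatic nitrogen proves far more sensitive than the first pair showed: a 2800-fold higher number from compound 2 to compound 3 (3.44 log units; beyond the scatter), a larger move than the earlier 28-fold lower number from compound 1 to compound 2 (1.45 log units; beyond the scatter), and compound 3 now has the highest number of the three. Direct attachment of the ring does not account for the whole change, since two directly attached groups still differ widely, with a 97-fold higher number from compound 1 to compound 3 (1.99 log units; beyond the scatter), although that pair also differs in ring size, in the ring nitrogen and in the acetyl group. No supporting data are available to explain the size of either new step.

The compounds shown do not separate the contributions of the methylene link, the ring nitrogen and the acetyl group, as all three change together from compound 2 to compound 3. A plain cyclohexyl, a piperidin-4-yl carrying a free amine and a 1-acetylpiperidin-4-ylmethyl group on the same nitrogen would each bear on one part of this question.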